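The compounds below may be only part of what the source reports. "The series", "measured", "known", "first", "only" and "open" are said of these compounds alone.

Compound 1 `O=C(Nc1nc2ccc(C(F)(F)F)cc2s1)C1CC1` and compound 2 `O=C(Nc1nc2cc(F)c(C(F)(F)F)cc2s1)C1CC1` share a core. In an ADME assay on H9c2 cells (Rattus norvegicus) for cytotoxicity (on this read-out lower numbers stand for stronger inhibition and higher numbers for weaker inhibition), compound 1 gives > 50000 nM, which is a limit of the assay and not a number. In this assay compound 2 gives > 50000 nM, which is also only a limit. Within the data shown here, the one measured step that bears on what follows is a step that the two limits leave unreadable from compound 1 to compound 2, fluoro in place of hydrogen on an aromatic carbon. All the evidence so far is the limit of > 50000 nM in this assay, at which 2 of the 2 values shown sit.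

Compound 3 `Cc1cc2nc(NC(=O)C3CC3)sc2cc1C(F)(F)F` differs from compound 2 by one change, (methyl in place of fluoro on an aromatic carbon), ortho to a trifluoromethyl group. Among the measured compounds shown here, with no readable step size to draw on, and with the limit of > 50000 nM in this assay, at which 2 of the 2 values shown sit, as the only guide, no step beyond the scatter is expected in this assay. The estimated change is a step that the limit leaves unreadable from compound 2 to compound 3. For compound 3 the expected value is 60000 nM, with an estimated range from 30000 nM to 120000 nM, and a report of only a limit is likely.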

Compound 3, half-maximal inhibitory concentration: 36000 nM
Compound 3: middle estimate off by 1.7-fold (0.22 log units), on the high side, within the range that was stated.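

Of the three compounds, only compound 3 gives a real number in this assay and not a limit, so methyl on this aromatic carbon, ortho to a trifluoromethyl group, brings the read-out within measurable range. Methyl in place of fluoro gives an at least 1.3-fold lower number from compound 2 to compound 3 (0.14 log units; that floor lies within the scatter), and methyl in place of hydrogen gives an at least 1.3-fold lower number from compound 1 to compound 3 (0.14 log units; that floor lies within the scatter). Each of these is only a floor, so the true steps may be larger, but neither is shown to go beyond the usual scatter.

As far as these compounds go, whether an amine, a methoxy group or a longer chain such as propyl on this carbon would give a lower number in this assay remains open. Also open is how far the true values of compound 1 and compound 2 lie past their limit, and most of the evidence is still of that kind: the limit of > 50000 nM in this assay, at which 2 of the 3 values shown sit.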